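This account rests on a few compounds, and the source may have more. Where it says the series, first, only, none or still open, it means among the compounds named here.

Working notes on the series.

Compound 1 `COc1ccccc1N1C(=O)C(C)SC1c1cccc(C(=O)NCCCCc2ccccc2)c1` carries a 2-methoxyphenyl on the amide-type nitrogen of the shared core. In a functional assay on 143B cells (Homo sapiens) for inhibition, read by CCK-8 assay, with a stated time of 72 h, tested at 1 uM (on this read-out higher numbers stand for more inhibition at the one concentration tested (going by the name of the read-out) and lower numbers for less inhibition), compound 1 gives 61%, the highest of the three numbers in hand. Compound 3 `COc1cccc(OC)c1N1C(=O)CSC1c1cccc(C(=O)NCCCCc2ccccc2)c1`, with a 2,6-dimethoxyphenyl in that position, gives 31%, a number beyond the scatter below compound 1. Compound 2 `COc1ccc(OC)c(N2C(=O)CSC2c2cccc(C(=O)NCCCCc3ccccc3)c2)c1`, with a 2,5-dimethoxyphenyl there, gives 2%, the furthest from compound 1 and again beyond the scatter. Within the data shown here, the one single-point step measured so far, a number 29 percentage points higher from compound 2 to compound 3 (beyond the scatter), concerns the dimethoxyphenyl pattern only.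

Compound 4 `CCOc1ccccc1N1C(=O)C(C)SC1c1cccc(C(=O)NCCCCc2ccccc2)c1` differs from compound 1 as follows: methyl in place of hydrogen on a saturated chain carbon bound to an oxygen on an aromatic ring. Among the measured compounds shown here, no measured step touches the alkoxy chain on the aryl ring; the dimethoxyphenyl step between compound 2 and compound 3 alters a different part of the molecule and offers no guide to methyl in place of hydrogen here. The change is a single carbon with no ring, no donor and no acceptor added. With nothing in the data to point either way, the expected step of a number 6 percentage points lower from compound 1 to compound 4 (within the scatter) is none beyond the scatter, with a wide range to reflect the absent precedent. Compound 4 is therefore estimated at 55%, between 30% and 75%.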

Compound 4, a percentage reported as inhibition, at one concentration (the size of the read-out at that concentration, not a potency): 53%
Estimate against measurement, compound 4: 2 percentage points above, within the range that was stated.
By their numbers in this assay, from the lowest: compound 2; then compound 3; then compounds 4 and 1 (each within the scatter of the next).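

In this assay, among these compounds, the first measured change to the alkoxy chain on the aryl ring, 2-methoxyphenyl to 2-ethoxyphenyl, reads a number 8 percentage points lower from compound 1 to compound 4 (within the scatter). On the core of compound 1, this position therefore takes methyl in place of hydrogen on a saturated chain carbon bound to an oxygen on an aromatic ring with no step beyond the scatter, something the dimethoxyphenyl step could not show. The series data offer no independent measurement that would account for this result.

Going by these compounds, whether a longer chain on that oxygen, such as propoxy, or a branched one, such as isopropoxy, stays within the scatter of compound 1 remains open, as does the reading for a 2-hydroxyphenyl or a 2-(dimethylamino)phenyl in the same place. On these data alone, it is also open whether methoxy to ethoxy reads the same way on other members, since this single step comes from the core of compound 1 alone.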